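Hydroxyphenyl isomer of the trifluoromethylphenyl compound

This account rests on a few compounds, and the source may have more. Where it says the series, first, only, none or still open, it means among the compounds named here.

Compound 3 `Oc1cccc(-c2cc(-c3ccc(C(F)(F)F)cc3)cc(-c3cccc(O)c3)n2)c1` sits at the edge of a functional assay on HeLa cells (Homo sapiens) for inhibition; on this read-out higher numbers stand for weaker inhibition and lower numbers for stronger inhibition: in this assay compound 3 gives > 50000 nM, which is a limit and not a number. It coincides with the limit of > 50000 nM in this assay, at which 1 of the 3 values shown sits. Compound 4 `Oc1ccc(-c2cc(-c3ccc(C(F)(F)F)cc3)cc(-c3cccc(O)c3)n2)cc1` differs from compound 3 only in 4-hydroxyphenyl in place of 3-hydroxyphenyl on an aromatic carbon. Within the data shown here, no measured step moves a hydroxyphenyl group. Among the measured compounds shown here, the only measured step, a 1.0-fold lower number from compound 1 to compound 2 (0.00 log units; within the scatter), moves a fluorine on the other aryl group, with compound 1 `Oc1ccc(-c2cc(-c3ccccc3F)cc(-c3cccc(O)c3)n2)cc1` giving 14300 nM and compound 2 `Oc1ccc(-c2cc(-c3cccc(F)c3)cc(-c3cccc(O)c3)n2)cc1` giving 14200 nM in this assay. That step bears only loosely on compound 4. The expected step of an at least 1.1-fold lower number from compound 3 to compound 4 (0.04 log units; that floor lies within the scatter) in this assay is therefore small. Compound 4 is estimated at 45000 nM in this assay, within a range from 15000 nM to 150000 nM, and another limit is expected to be likely.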

Compound 4, half-maximal inhibitory concentration: 17300 nM
Estimate against measurement, compound 4: 2.6-fold (0.42 log units) above; measured number inside the range.
By their numbers in this assay, from the lowest: compounds 2, 1 and 4 (each within the scatter of the next). At a limit, above all of these: compound 3.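

Moving the hydroxyl from 3-hydroxyphenyl to 4-hydroxyphenyl at this place, next to the ring nitrogen, gives the first step beyond the scatter in this assay: an at least 2.8-fold lower number from compound 3 to compound 4 (0.46 log units; beyond the scatter). Compound 3 stands at a limit, so this step is only a floor: the limit of > 50000 nM in this assay, at which 1 of the 4 values shown sits. With 4-hydroxyphenyl held, changing the other aryl group leaves the values unseparated: a 1.2-fold higher number from compound 2 to compound 4 (0.09 log units; within the scatter) and a 1.2-fold higher number from compound 1 to compound 4 (0.08 log units; within the scatter).

Going by these compounds, the true size of the step from compound 3 remains open. So does what a methoxy or an amino group would give in place of the hydroxyl on this ring.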